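This account rests on a few compounds, and the source may have more. Where it says the series, first, only, none or still open, it means among the compounds named here.

Measured so far:
compound 1, `O=C1NCCc2nc(C#Cc3ccccc3)sc21`, gives > 10000 nM.
compound 2, `CC(=O)N1CCc2nc(C#Cc3ccccc3)sc2C1`, gives 90 nM.

For compound 1, an assay on HEK293 cells for negative allosteric modulation of metabotropic glutamate receptor 5 (Homo sapiens), read by FLIPR, with a stated time of 1 h (a lower number here means a stronger inhibitor, a higher number a weaker inhibitor), reports only a limit, not a number; compound 1 sits at the limit of > 10000 nM in this assay, at which 1 of the 2 values shown sits. Going by the values given here, compound 2 is the only compound with a number in this assay, and no step between the two is worked out, since their structures differ in more than one place.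

Compound 3, `CC1CCCC(C(=O)N2CCc3nc(C#Cc4ccccc4)sc3C2)C1`, carries the change 3-methylcyclohexyl in place of methyl on a carbonyl carbon relative to compound 2. Among the compounds with values here, no measured step covers a change of this kind, so the expected step from compound 2 to compound 3 is a 1.5-fold lower number from compound 2 to compound 3 (0.18 log units; within the scatter), likely within the scatter or slightly toward a stronger inhibitor. Compound 3 is expected at 60 nM, in the range 15 nM to 400 nM.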

Compound 3, half-maximal inhibitory concentration: > 10000 nM
Compound 3: no number, only a limit; the forecaster's own chance of this, stated with the estimate: 5%; middle value at least 160-fold (2.22 log units) away from the limit.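

The carbonyl carbon is a sensitive position: in this assay, 3-methylcyclohexyl in place of methyl gives an at least 110-fold higher number from compound 2 to compound 3 (2.04 log units; beyond the scatter). With the shared core unchanged, this single change is enough to lose the measurable inhibition seen with methyl. Compound 3 reports a limit, not a number, and sits here: the limit of > 10000 nM in this assay, at which 2 of the 3 values shown sit.

Only methyl and 3-methylcyclohexyl are compared at this position, so the ring and its methyl cannot be separated. Where ethyl, unsubstituted cyclohexyl or a dimethylamino group would fall remains open.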